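From 4-fluorophenyl to thiophen-3-yl on the shared core

This account rests on a few compounds, and the source may have more. Where it says the series, first, only, none or still open, it means among the compounds named here.

In a functional assay on MDA-MB-468 cells (Homo sapiens) for antiproliferative activity, read by sulforhodamine B assay, with a stated time of 48 h (on this read-out higher numbers stand for weaker inhibition and lower numbers for stronger inhibition), compound 1 `COc1ccc(-c2nsc3c2NC(=O)CC3c2cccc(OC)c2)cc1` gives 395 nM, compound 2 `COc1ccc(-c2nsc3c2NC(=O)CC3c2cccc(F)c2)cc1` gives 1940 nM, and compound 3 `COc1ccc(-c2nsc3c2NC(=O)CC3c2ccc(F)cc2)cc1` gives 2350 nM. Compound 3 thus sits level with compound 2, as a 1.2-fold higher number from compound 2 to compound 3 (0.08 log units; within the scatter) lies within the scatter, whereas a 5.9-fold higher number from compound 1 to compound 3 (0.77 log units; beyond the scatter) lies beyond it. Compound 4 `COc1ccc(-c2nsc3c2NC(=O)CC3c2ccsc2)cc1` carries thiophen-3-yl in place of 4-fluorophenyl on a saturated ring carbon. Two measured steps change the ring at this carbon, and the larger, a 5.9-fold higher number from compound 1 to compound 3 (0.77 log units; beyond the scatter), is modest, but neither introduces a five-membered ring. In this assay, the expected change is small and toward a lower number, not beyond the scatter: a 1.8-fold lower number from compound 3 to compound 4 (0.26 log units; within the scatter). For compound 4, the estimated value is 1300 nM, with an expected range of 400 nM to 4000 nM.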

Compound 4, half-maximal inhibitory concentration: 117 nM
The estimate for compound 4 lay 11-fold (1.05 log units) above the measured number; the measured number lies below the stated range.
By their numbers in this assay, from the lowest: compound 4; then compound 1; then compounds 2 and 3 (each within the scatter of the next).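

In this assay, the ring on this saturated ring carbon moves the number much further than the phenyl changes suggested: thiophen-3-yl gives a 20-fold lower number from compound 3 to compound 4 (1.30 log units; beyond the scatter) and a 17-fold lower number from compound 2 to compound 4 (1.22 log units; beyond the scatter), both large. It also improves on the 3-methoxyphenyl group, with a 3.4-fold lower number from compound 1 to compound 4 (0.53 log units; beyond the scatter) as a modest step, leaving compound 4 with the lowest number of the four. Nothing at hand explains this gain. The compounds shown leave open whether the sulfur or the five-membered ring itself matters, which a furan-3-yl group at this carbon would help separate. They also leave open whether thiophen-2-yl would serve equally.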